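Swapping the aryl group on the ring nitrogen: a solubility estimate

The compounds below may be only part of what the source reports. "The series", "measured", "known", "first", "only" and "open" are said of these compounds alone.

Measured compounds:
Compound 1, `C#Cc1cccc(N2C(=O)CSC2c2cccc(C(=O)NCCCCc3ccccc3)c2)c1`: 10000 nM in a physicochemical assay for solubility, read by turbidimetry, measured as kinetic solubility, at pH 7.4; on this read-out higher numbers stand for higher solubility and lower numbers for lower solubility
Compound 2, `CC(F)(F)c1cccc(N2C(=O)CSC2c2cccc(C(=O)NCCCCc3ccccc3)c2)c1`: 2000 nM in this assay

On these two numbers compound 2 stands lowest, its nearest neighbour being compound 1, with a 5.0-fold lower number from compound 1 to compound 2 (0.70 log units; beyond the scatter) separating them. Compound 3, `O=C(NCCCCc1ccccc1)c1cccc(C2SCC(=O)N2c2ccc(C3CC3)cc2)c1`, has not yet been measured. It differs from compound 2 in one place: a group of 9 heavy atoms (9 carbon; one three-membered non-aromatic ring of carbon only, one six-membered aromatic ring of carbon only) in place of a group of 10 heavy atoms (8 carbon, 2 fluorine; one six-membered aromatic ring of carbon only), on an amide-type nitrogen in a ring. Within the data shown here, the only measured step, from compound 1 to compound 2, shows that changing the group on this same aromatic ring can move the read-out by a modest amount, but neither of the two measured compounds carries a 4-cyclopropylphenyl, so no step directly covers this change. In this assay compound 3 is therefore expected to give a number close to that of compound 2, with a 1.3-fold higher number from compound 2 to compound 3 (0.10 log units; within the scatter) as the estimated step, well within a modest shift. The estimated value for compound 3 is 2500 nM, expected to fall between 800 nM and 8000 nM.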

Compound 3, solubility: 2000 nM
Beside the measured number, compound 3's estimate is 1.3-fold (0.10 log units) above it; low and high end bracket the measured number.
By their numbers in this assay, from the lowest: compounds 2 and 3 (each within the scatter of the next); then compound 1.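

In this assay, changing the aryl group on the amide-type nitrogen in a ring once more gives no change at the digits printed from compound 2 to compound 3 (within the scatter), so the group carrying 1,1-difluoroethyl and 4-cyclopropylphenyl cannot be told apart here, even though the two fluorine atoms leave and a three-membered carbon ring enters. Putting 4-cyclopropylphenyl in place of 3-ethynylphenyl gives a 5.0-fold lower number from compound 1 to compound 3 (0.70 log units; beyond the scatter), so the gap first seen with 1,1-difluoroethyl now appears with a second group, and 3-ethynylphenyl alone goes with the higher number among these three compounds. No measurement at hand offers a reason for either step.

As far as these compounds go, it remains open whether the ethynyl group itself or its place on the aryl ring goes with the higher number. Also open, from the compounds shown here alone, is how an aryl group bearing an amine or a carboxylic acid would read in this assay.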